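A few compounds are considered here, and "the series" means these few. Any claim that something is new, unique, unknown or untested is made for them only; others in the source may bear on it.

In an ADME assay on HII4E cells (Mus musculus) for cytotoxicity, read by MTT assay, with a stated time of 48 h (on this read-out lower numbers stand for stronger inhibition and higher numbers for weaker inhibition), compound 2 (`C#CCNC(=O)CO[C@H]1O[C@H](COC(C)=O)C=C(OC(C)=O)/C1=C\C(=O)OCC`) gives 257 ug/mL. This is second highest of the three numbers, though it lies within the scatter of compound 1 (`CCCCCCCCCCCCNC(=O)CO[C@H]1O[C@H](COC(C)=O)C=C(OC(C)=O)C1=O`) at 136 ug/mL, while compound 3 (`C=CCCCCn1cc(CN(CC=C)C(=O)CO[C@H]2O[C@H](COCC=C)[C@H](OCC=C)[C@H](O)[C@H]2OCC=C)nn1`) reads clearly higher at 1190 ug/mL. Compound 4 (`CCOC(=O)/C=C1\C(OC(C)=O)=C[C@@H](COC(C)=O)O[C@@H]1OCC(=O)NCc1cn(Cc2ccccc2)nn1`) carries 1-benzyl-1H-1,2,3-triazol-4-yl in place of ethynyl on a saturated chain carbon bound to an amide-type nitrogen. For the measured compounds named here, no two measured compounds differ in only one place, so nothing measured shows directly what such a change does. The expected step of a 1.2-fold lower number from compound 2 to compound 4 (0.07 log units; within the scatter) is small, within the scatter, with no confident direction. The estimate for compound 4 is 220 ug/mL, with an expected range of 80 ug/mL to 600 ug/mL.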

Compound 4, half-maximal inhibitory concentration: 12000 ug/mL
The estimate for compound 4 lay 55-fold (1.74 log units) below the measured number; the measured number lies above the stated range.
By their numbers in this assay, from the lowest: compounds 1 and 2 (each within the scatter of the next); then compound 3; then compound 4.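

In this assay there is a 47-fold higher number from compound 2 to compound 4 (1.67 log units; beyond the scatter) when 1-benzyl-1H-1,2,3-triazol-4-yl replaces ethynyl on a saturated chain carbon bound to an amide-type nitrogen. For the compounds shown here, this is the first direct sign that the number is highly sensitive to the group at this position, with the larger two-ring group giving much weaker inhibition. Nothing here explains the size of this step. Still open, on these data alone, is whether the triazole ring or the benzyl group accounts for the step, and how a different group here, such as an amine or a carboxylic acid, would read.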